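This account rests on a few compounds, and the source may have more. Where it says the series, first, only, none or still open, it means among the compounds named here.

Measured compounds:
Compound 1 `COc1ccc2c(=O)c(/C=C/C(=O)Nc3ccc(Cl)cc3)coc2c1` gives in a functional assay on L02 cells (Homo sapiens) for inhibition, read by MTT assay, with a stated time of 48 h (on this read-out lower numbers stand for stronger inhibition and higher numbers for weaker inhibition), only a limit, > 200000 nM.
Compound 2 `Cc1ccc(CNC(=O)/C=C/c2coc3cc(O)ccc3c2=O)cc1` gives in this assay only a limit, > 200000 nM.
Compound 3 `COc1ccc(NC(=O)/C=C/c2coc3cc(O)ccc3c2=O)cc1` gives in this assay only a limit, > 200000 nM.

Compound 1 therefore stands at the limit of this assay, not at a number, and the two other measured compounds stand at the same limit, so no order among the three can be read. Among the measured compounds shown here, the only step between measured compounds that differ in one place, a step that the two limits leave unreadable from compound 2 to compound 3, runs from one limit to another and its size cannot be read.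

The unmeasured compound 4 `COc1ccc2c(=O)c(/C=C/C(=O)NCc3ccc(F)cc3F)coc2c1` differs from compound 1 by 2,4-difluorobenzyl in place of 4-chlorophenyl on an amide-type nitrogen. For the measured compounds named here, no measured step touches this change, so nothing among the measured compounds tells its size or direction. The one thing that is known is the limit of > 200000 nM in this assay, at which 3 of the 3 values shown sit, which places every measured compound at the limit. Compound 4 is therefore expected to report the same limit, with an estimate of 200000 nM and a range from 60000 nM to 600000 nM. The step of a number no higher from compound 1 to compound 4 (the limit leaves the size open) is accordingly expected to be none beyond the scatter.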

Compound 4, half-maximal inhibitory concentration: > 200000 nM
Compound 4: only a limit was reported (the forecaster's own chance of this, stated with the estimate: 85%); the middle value sits exactly at the limit.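

Among the compounds shown here, compound 1 and compound 4 both give only a limit in this assay, so putting 2,4-difluorobenzyl in place of 4-chlorophenyl yields no step that can be read. The compounds shown leave open whether any change among them alters inhibition, as all share one reading: the limit of > 200000 nM in this assay, at which 4 of the 4 values shown sit.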